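The source may report more compounds than this note shows. Statements on the series, on what has been measured and on what is new or still open speak of the compounds shown alone.

Measured so far:
Compound 1, `CC1=CC[C@@H]([C@@](C)(O)CCCC(C)(C)NC(=S)N/N=C\c2ccccc2)CC1`: 20900 nM
Compound 2, `COc1ccc(/C=N\NC(=S)NC(C)(C)CCC[C@](C)(O)[C@@H]2CC=C(C)CC2)cc1`: 34900 nM

Both compounds were tested in a functional assay on K562 cells (Homo sapiens) for cytotoxicity, read by sulforhodamine B assay; on this read-out lower numbers stand for stronger inhibition of growth and higher numbers for weaker inhibition of growth. Among the compounds with values here, compound 2 holds the highest of the two numbers, but the one step between them, a 1.7-fold higher number from compound 1 to compound 2 (0.22 log units; within the scatter), lies within the scatter, so on this read-out the two compounds cannot be told apart.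

Compound 3, `CC1=CC[C@@H]([C@@](C)(O)CCCC(C)(C)NC(=S)N/N=C\c2ccc(O)cc2)CC1`, has not yet been measured in this assay. It differs from compound 2 in one place: hydrogen in place of methyl on an oxygen on an aromatic ring. Within the data shown here, only one measured step touches this part of the structure, the step from compound 1 to compound 2, a 1.7-fold higher number from compound 1 to compound 2 (0.22 log units; within the scatter), which put the methoxy group in place and produced no change beyond the scatter. Among the measured compounds shown here, no measured step trades methoxy for hydroxy, so there is nothing to point in either direction. The expected step is therefore a 1.2-fold lower number from compound 2 to compound 3 (0.10 log units; within the scatter), one that stays within the scatter. Compound 3 is estimated to give 28000 nM, with a range from 12000 nM to 65000 nM.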

Compound 3, concentration for total growth inhibition: 31100 nM
The estimate for compound 3 lay 1.1-fold (0.05 log units) below the measured number, within the range that was stated.
By their numbers in this assay, from the lowest: compounds 1, 3 and 2 (each within the scatter of the next).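

In this assay, trading methoxy for hydroxy on this aromatic ring gives a 1.1-fold lower number from compound 2 to compound 3 (0.05 log units; within the scatter), so whether the oxygen carries a methyl or a hydrogen makes no difference that this read-out can detect. Within the data shown here, the second new comparison adds something the earlier compounds could not show, a hydroxy group set against hydrogen on the same aromatic carbon: a 1.5-fold higher number from compound 1 to compound 3 (0.17 log units; within the scatter). Hydrogen, methoxy and hydroxy in this place therefore cannot be told apart, although nothing available explains this result or links it to any property of these groups.

On these data alone, the three compounds cover only a small set of groups, so it remains open whether an amine, a carboxylic acid or a bromine atom on that aromatic carbon would give a number beyond the scatter. As far as these compounds go, it also remains open whether changes elsewhere on the shared core, such as a shorter or longer chain, would separate compounds more clearly than this change to the ring has done.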